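Dimethylamide in place of the valine acid

The compounds below may be only part of what the source reports. "The series", "measured", "known", "first", "only" and "open" are said of these compounds alone.

Compound 1 `CC(C)[C@@H](NC(=O)/C=C/c1ccncc1-c1ccc2ccccc2c1)C(=O)O` carries the (1-carboxy-2-methylpropyl)amino group on its carbonyl carbon. In a functional assay on HCT-116 cells (Homo sapiens) for inhibition, read by MTT assay, with a stated time of 72 h (a higher number here means a weaker inhibitor of growth, a lower number a stronger inhibitor of growth), compound 1 gives "not determined" (no result reported), so it stands nowhere on the numbers shown. Two related compounds do have results. Compound 2 `CNC(=O)/C=C/c1ccncc1-c1ccc2[nH]ccc2c1` reaches only a limit of the assay, > 30000 nM in this assay. Compound 3 `CCOC(=O)/C=C/c1ccncc1-c1ccc2cc[nH]c2c1` gives 2140 nM in this assay. The account notes that (the limit of > 30000 nM in this assay, at which 1 of the 3 values shown sits).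

Compound 4 `CN(C)C(=O)/C=C/c1ccncc1-c1ccc2ccccc2c1` differs from compound 1 in one place: dimethylamino in place of (1-carboxy-2-methylpropyl)amino on a carbonyl carbon. Compound 1 has no number in this assay, so the step to compound 4 has no measured starting point, and its size and direction cannot be read from the data; the expectation rests on compounds 2 and 3 alone. Compound 4 is expected to give about 15000 nM in this assay, within a range from 3000 nM to 30000 nM, with a real chance that only a limit is reported.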

Compound 4, concentration for 50% growth inhibition: 4540 nM
Estimate against measurement, compound 4: 3.3-fold (0.52 log units) above, and the stated range covers the measured number.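

For the compounds shown here, compound 1 has no number in this assay, so no step from it to compound 4 can be read. The compounds shown leave open what exchanging (1-carboxy-2-methylpropyl)amino for dimethylamino on a carbonyl carbon does to growth inhibition, and what number compound 2 would have: the limit of > 30000 nM in this assay, at which 1 of the 4 values shown sits.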